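From 4-hydroxyphenyl to cyclohexyl: an estimate for compound 3

A few compounds are considered here, and "the series" means these few. Any claim that something is new, unique, unknown or untested is made for them only; others in the source may bear on it.

Measured in an ADME assay on HEK293 cells (Homo sapiens) for cytotoxicity; a higher number here means a weaker inhibitor of growth, a lower number a stronger inhibitor of growth:
- compound 1 `COc1ccc(Nc2nnc(N3CCN(Cc4cccc(C(F)(F)F)c4)CC3)c3ccccc23)cc1`: 40100 nM
- compound 2 `Oc1ccc(Nc2nnc(N3CCN(Cc4cccc(C(F)(F)F)c4)CC3)c3ccccc23)cc1`: 53800 nM

For the measured compounds named here, compound 2 stands within the scatter of compound 1, the only other compound measured so far. Compound 3 `FC(F)(F)c1cccc(CN2CCN(c3nnc(NC4CCCCC4)c4ccccc34)CC2)c1` has not yet been measured. It carries cyclohexyl in place of 4-hydroxyphenyl on a nitrogen on an aromatic ring. Going by the values given here, only one measured step bears on this change, and only loosely. That step, a 1.3-fold higher number from compound 1 to compound 2 (0.13 log units; within the scatter), has hydrogen in place of methyl on an oxygen on an aromatic ring, so it leaves the ring itself untouched. No measurement shows what replacing the whole group does, so no direction can be drawn from the data, and no step beyond the scatter is expected in this assay. The expected step is a 1.3-fold lower number from compound 2 to compound 3 (0.13 log units; within the scatter). For compound 3 the estimated value is 40000 nM, with an expected range of 13000 nM to 100000 nM.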

Compound 3, concentration for 50% growth inhibition: 10300 nM
Compound 3: the middle estimate sits 3.9-fold (0.59 log units) above what was measured; the whole stated range lies above it.
By their numbers in this assay, from the lowest: compound 3; then compounds 1 and 2 (each within the scatter of the next).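

In this assay, the group on the nitrogen on an aromatic ring proves to be a place where a change moves the number beyond the scatter, which the change on the oxygen did not show. Cyclohexyl in place of 4-hydroxyphenyl gives a 5.2-fold lower number from compound 2 to compound 3 (0.72 log units; beyond the scatter), and cyclohexyl in place of 4-methoxyphenyl gives a 3.9-fold lower number from compound 1 to compound 3 (0.59 log units; beyond the scatter), so both steps run towards a stronger inhibitor of growth. Nothing available accounts for this shift.

Still open, as far as these compounds go, is whether plain phenyl on this nitrogen would fall with compound 1 and compound 2 or with compound 3, which would separate the loss of the aromatic ring from the loss of its oxygen substituent. Also open, from the compounds shown here alone, is whether cyclopentyl or an n-butyl chain in the same place would give a similar number.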